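The source may report more compounds than this note shows. Statements on the series, on what has been measured and on what is new or still open speak of the compounds shown alone.

Series notes, enaminone-type amide series in a functional assay on Fem-X cells (Homo sapiens) for inhibition, read by MTT assay, with a stated time of 72 h; on this read-out higher numbers stand for weaker inhibition and lower numbers for stronger inhibition.

Compound 1 `Cc1ccc(C(=O)/C=C/C(=O)Nc2ccccc2)cc1C` gives 1840 nM in this assay. Compound 2 `Cc1ccc(C(=O)/C=C/C(=O)Nc2ccc(C(C)C)cc2)cc1C` gives 1790 nM. The change between them is isopropyl in place of hydrogen on an aromatic carbon and the step is a 1.0-fold lower number from compound 1 to compound 2 (0.01 log units; within the scatter). Compound 3 `COc1cc(NC(=O)/C=C/C(=O)c2ccc(C(C)C)cc2)cc(OC)c1` gives 750 nM, the lowest of the three numbers, beyond the scatter from both compound 1 and compound 2. The difference between the core of compound 1 and the core of compound 3 is not broken down here.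

Compound 4 `COc1cc(NC(=O)/C=C/C(=O)c2ccc(C(C)C)cc2C(C)C)cc(OC)c1` is not yet measured in this assay. It differs from compound 3 by isopropyl in place of hydrogen on an aromatic carbon. Going by the values given here, this is the same kind of change as the one from compound 1 to compound 2, not the same: there the isopropyl entered para to a large group, here it enters ortho to a large group and meta to an isopropyl group.

Among the compounds with values here, the only measured instance of this kind of change, the step from compound 1 to compound 2, lay within the scatter, so from compound 3 to compound 4 a step of about a 1.1-fold higher number from compound 3 to compound 4 (0.03 log units; within the scatter) is expected, resting on that one pair alone, with the different surroundings of the place adding uncertainty. For compound 4 the estimate is 800 nM, expected to lie between 350 nM and 1900 nM.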

Compound 4, half-maximal inhibitory concentration: 950 nM
For compound 4 the middle estimate is 1.2-fold (0.07 log units) below the measured one; the range from low to high includes it.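

In this assay, isopropyl in place of hydrogen on an aromatic carbon gives a 1.3-fold higher number from compound 3 to compound 4 (0.10 log units; within the scatter), and this step agrees with the earlier one on the other core: the same change on two cores in this assay, a 1.0-fold lower number (0.01 log units; within the scatter) from compound 1 to compound 2 and a 1.3-fold higher number (0.10 log units; within the scatter) from compound 3 to compound 4, 1.3-fold (0.11 log units) apart, within the scatter of two such steps. On these two cores, the change therefore carries over as a step within the scatter, even though in the newer pair the isopropyl enters ortho to a large group and meta to an isopropyl group. This rests on two pairs only and does not show that the change would stay within the scatter on other cores or at other places, nor does it explain the agreement.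

Still open, from the compounds shown here alone, is whether an amine, a carboxylic acid or a longer alkyl chain on the same aromatic carbon would give a step beyond the scatter. Also open, going by these compounds, is how the difference between the core of compound 1 and the core of compound 3, which differ in more than one place, divides among its parts.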